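The source may report more compounds than this note shows. Statements on the series, on what has been measured and on what is new or still open speak of the compounds shown alone.

Compound 3 `Cc1occc1-c1nnc(SCC(=O)Nc2cccc(F)c2)n1Cc1ccco1` belongs to a small set of three compounds that share one core and differ only in the aryl group on the amide-type nitrogen. In a functional assay on CHO cells for antagonist activity at Orexin/Hypocretin receptor type 1 (Homo sapiens), read by FLIPR and calcium flux (on this read-out lower numbers stand for stronger inhibition and higher numbers for weaker inhibition), compound 3 gives > 15800 nM, which is a limit of the assay and not a number. Compound 1 `Cc1cccc(NC(=O)CSc2nnc(-c3ccoc3C)n2Cc2ccco2)c1C` likewise gives only a limit in this assay, > 15800 nM. Going by the values given here, compound 2 `COc1ccc(C)cc1NC(=O)CSc1nnc(-c2ccoc2C)n1Cc1ccco1` is the single member with a measured number, giving 2510 nM in this assay. The step of an at least 6.2-fold lower number from compound 1 to compound 2 (0.79 log units; beyond the scatter) is therefore at least modest, the step of an at least 6.2-fold higher number from compound 2 to compound 3 (0.79 log units; beyond the scatter) runs the other way, and the step that the two limits leave unreadable from compound 1 to compound 3 cannot be read because both values sit at the limit of > 15800 nM in this assay, at which 2 of the 3 values shown sit. Compound 4 `Cc1occc1-c1nnc(SCC(=O)Nc2ccc(N(C)C)cc2)n1Cc1ccco1` has not been measured in this assay; it differs from compound 3 by 4-(dimethylamino)phenyl in place of 3-fluorophenyl on an amide-type nitrogen. Of the measured steps, an at least 6.2-fold higher number from compound 2 to compound 3 (0.79 log units; beyond the scatter) and an at least 6.2-fold lower number from compound 1 to compound 2 (0.79 log units; beyond the scatter) bear on it, and both are at least modest. Among the compounds with values here, since no measured compound carries a 4-(dimethylamino)phenyl, the expected step of an at least 1.7-fold lower number from compound 3 to compound 4 (0.24 log units; that floor lies within the scatter) is uncertain in size and is set small. Compound 4 is expected at 9000 nM, with a range from 1500 nM to 40000 nM.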

Compound 4, inhibition constant: 794 nM
The estimate for compound 4 lay 11-fold (1.05 log units) above the measured number; the measured number lies below the stated range.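

Placing 4-(dimethylamino)phenyl on the amide-type nitrogen in place of 3-fluorophenyl gives an at least 19-fold lower number from compound 3 to compound 4 (1.29 log units; beyond the scatter), and in place of 2,3-dimethylphenyl it gives an at least 19-fold lower number from compound 1 to compound 4 (1.29 log units; beyond the scatter). Going by these compounds alone, it also goes past the only earlier measured number, with a 3.2-fold lower number from compound 2 to compound 4 (0.50 log units; beyond the scatter), which makes compound 4 the most potent of the four in this assay. Until now only the 2-methoxy-5-methylphenyl of compound 2 had given a measured number at this position, and an aryl group carrying a dimethylamino substituent now gives a lower one.

On these data alone, whether a 4-aminophenyl, a 4-(diethylamino)phenyl or a 4-carboxyphenyl on the amide-type nitrogen would match compound 4 stays open. The full size of the steps from compound 1 and compound 3 also stays open, because each starts from a limit: the limit of > 15800 nM in this assay, at which 2 of the 4 values shown sit.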